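The source may hold more compounds than are shown below. What is called first, only, known or untested is meant among the compounds shown, and "the series" means these compounds.

In a functional assay on THP-1 cells (Homo sapiens) for inhibition (a higher number here means a weaker inhibitor, a lower number a stronger inhibitor), compound 1 `Clc1cccc(-c2nnnn2Cc2ccccn2)c1Cl` gives 2000 nM and compound 2 `Cc1ncccc1Cn1nnnc1-c1cccc(Cl)c1Cl` gives 200 nM, so compound 2 holds the lower of the two numbers and is the stronger inhibitor of the pair. Next is compound 3 `Cc1nc(C)c(Cn2nnnc2-c2cccc(Cl)c2Cl)s1`, not yet measured. The change from compound 2 is 2,4-dimethyl-1,3-thiazol-5-yl in place of 2-methylpyridin-3-yl on a saturated chain carbon bound to an aromatic nitrogen. Among the measured compounds shown here, one measured step bears on it, at the same place: a 10-fold lower number from compound 1 to compound 2 (1.00 log units; beyond the scatter), with 2-methylpyridin-3-yl in place of pyridin-2-yl. That modest step shows that the number can move with the group held at this place, but it does not show which feature of the group matters. No five-membered aromatic ring has been measured here. As far as these compounds go, with so little evidence, no step beyond the scatter is expected in this assay, and a move in either direction remains open. The expected change is a 1.3-fold higher number from compound 2 to compound 3 (0.10 log units; within the scatter). For compound 3 the estimated value is 250 nM, with an expected range of 70 nM to 900 nM.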

Compound 3, half-maximal inhibitory concentration: 251 nM
Compound 3: the middle estimate sits 1.0-fold (0.00 log units) below what was measured; measured number inside the range.
By their numbers in this assay, from the lowest: compounds 2 and 3 (each within the scatter of the next); then compound 1.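

In this assay the step of a 1.3-fold higher number from compound 2 to compound 3 (0.10 log units; within the scatter) shows that this position accepts one five-membered aromatic ring with 2 hetero atoms, one of them sulfur, in place of a six-membered aromatic ring, with no difference beyond the scatter. The step of an 8.0-fold lower number from compound 1 to compound 3 (0.90 log units; beyond the scatter) is beyond the scatter and close in size to the earlier step from pyridin-2-yl, so that step is not tied to a pyridine ring: 2,4-dimethyl-1,3-thiazol-5-yl and 2-methylpyridin-3-yl both stand apart from pyridin-2-yl in this assay. No measurement on these compounds gives a reason for this result, and the reading stays at the level of which groups on a saturated chain carbon bound to an aromatic nitrogen go with which numbers.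

Both groups that stand apart from pyridin-2-yl carry methyl, so the compounds shown cannot separate the methyl groups from the ring and its attachment, and an unsubstituted pyridin-3-yl or a plain phenyl would bear on that. Also open, as far as these compounds go, is how far the position goes beyond aromatic rings of this size, for instance with a saturated ring such as piperidine or with a group carrying an amine or a carboxylic acid.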